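Chloro for Nitro: a Single Change from Compound 3

The source may report more compounds than this note shows. Statements on the series, on what has been measured and on what is new or still open speak of the compounds shown alone.

The compounds are compared in a functional assay on CRL2813 cells (Homo sapiens) for cytotoxicity, read by sulforhodamine B assay, with a stated time of 5 days; a higher number here means a weaker inhibitor, a lower number a stronger inhibitor. Compound 1 `O=C(Nc1cccc(C(F)(F)F)c1)N[C@H]1CC[C@H](Oc2cccc(C(F)(F)F)c2)CC1` gives 1300 nM in this assay. Compound 2 `O=C(Nc1ccccc1C(=O)O)N[C@H]1CC[C@@H](Oc2ccc(F)cc2)CC1` is reported only as a limit, > 20000 nM, as noted here: the limit of > 20000 nM in this assay, at which 1 of the 3 values shown sits. Compound 3 `O=C(Nc1ccccc1[N+](=O)[O-])N[C@H]1CC[C@H](Oc2ccc(F)cc2)CC1` gives 3500 nM in this assay, which is the higher of the two actual numbers shown; the number for compound 1 lies lower, and that gap is beyond the usual scatter.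

The next compound, compound 4 `O=C(Nc1ccccc1Cl)N[C@H]1CC[C@H](Oc2ccc(F)cc2)CC1`, has not yet been measured in this assay. It differs from compound 3 in one place: chloro in place of nitro on an aromatic carbon. Among the measured compounds shown here, no pair of compounds already measured here differs in that same way, so there is no measured step of this kind to lean on. For this change the account expects no step beyond the usual scatter in this assay, in either direction. The estimate for compound 4 in this assay is therefore 3000 nM, with a range from 1200 nM to 8000 nM. That estimate means a step of a 1.2-fold lower number from compound 3 to compound 4 (0.07 log units; within the scatter) that is expected to stay within the scatter.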

Compound 4, half-maximal inhibitory concentration: 9100 nM
Compound 4: the middle estimate sits 3.0-fold (0.48 log units) below what was measured; measured number outside the range, above it.
By their numbers in this assay, from the lowest: compound 1; then compound 3; then compound 4. At a limit, above all of these: compound 2.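

In this assay, among the compounds shown here, the first measured step of this kind is a 2.6-fold higher number from compound 3 to compound 4 (0.41 log units; beyond the scatter), so replacing nitro with chloro on this aromatic carbon, ortho to a large group, gives a modestly weaker compound rather than leaving the number in place. The earlier compounds shown here could not show this, as none of them forms a pair differing only at this position, and this pair shows that the choice of group here can move the number. Nitro brings hydrogen-bond acceptors and a double bond that chloro lacks, but a single pair cannot separate these differences, and nothing measured here gives a cause for the step.

The compounds shown leave open how an amine, a nitrile or a methoxy group would fare on this same carbon, and whether plain hydrogen there would sit nearer compound 3 or compound 4. They also leave open whether the same change would give a step of similar size and direction on another aromatic position, or with a different group on the far ring of the shared core.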